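The source may report more compounds than this note shows. Statements on the series, on what has been measured and on what is new or still open speak of the compounds shown alone.

Working notes on the series. All three measured compounds share one core and differ in the amide substituent and in the fluorine pattern. Compound 1 `CN(C)C(=O)/C=C1\CCc2c(F)cc(F)cc21` carries a dimethylamide, and in a functional assay on the whole organism with Mus musculus as the target (a higher number here means that more compound is needed for the effect, a lower number that less compound is needed), compound 1 gives 50 mg/kg. Compound 2 `O=C(/C=C1\CCc2cc(F)cc(F)c21)NC1CC1` carries a cyclopropyl amide, and in this assay compound 2 gives 69 mg/kg. Compound 3 `CCCNC(=O)/C=C1\CCc2ccc(F)cc21` carries a propyl amide. In this assay compound 3 gives only a limit, > 100 mg/kg, so its place on the scale is not fixed. It sits at the limit of > 100 mg/kg in this assay, at which 1 of the 3 values shown sits, whereas compound 1 and compound 2 return measured numbers.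

Compound 4 `O=C(/C=C1\CCc2ccc(F)cc21)NC1CC1` differs from compound 3 in one place: cyclopropyl in place of propyl on an amide-type nitrogen. Among the measured compounds shown here, no pair of measured compounds differs in this place alone; compound 2 also carries the cyclopropyl amide but with a different fluorine pattern, so its value gives no clean step. The step from compound 3 to compound 4 is expected to be small, a number no higher from compound 3 to compound 4 (the limit leaves the size open), not beyond the scatter. Compound 4 is expected at 100 mg/kg, within 55 mg/kg to 200 mg/kg, with a fair chance of a limit again.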

Compound 4, dose for half-maximal effect: 66 mg/kg
Estimate against measurement, compound 4: 1.5-fold (0.18 log units) above; low and high end bracket the measured number.
By their numbers in this assay, from the lowest: compounds 1, 4 and 2 (each within the scatter of the next). At a limit, above all of these: compound 3.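

Among the compounds shown here, on the amide-type nitrogen, the change from propyl to cyclopropyl gives the first step that can be read with the fluorine pattern held constant: in this assay it gives an at least 1.5-fold lower number from compound 3 to compound 4 (0.18 log units; that floor lies within the scatter). As far as these compounds go, compound 3 holds only a limit, so this step is a floor and its full size stays unknown: the limit of > 100 mg/kg in this assay, at which 1 of the 4 values shown sits. With cyclopropyl in this place, compound 4 returns a measured number, which shows that this fluorine pattern can reach the measured range in this assay.

From the compounds shown here alone, whether a longer chain, such as butyl, or a larger ring, such as cyclobutyl, on this nitrogen would shift the number further remains open. Also open, going by these compounds, is whether the change from propyl to cyclopropyl would give a similar step under the other fluorine patterns.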